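A few compounds are considered here, and "the series" means these few. Any claim that something is new, unique, unknown or untested is made for them only; others in the source may bear on it.

Of the compounds shown here, two of this set have been tested. Compound 1 has the structure `COC(=O)c1ccc(Cl)cc1OC(=O)COc1cc(O)c2c(=O)cc(-c3ccccc3)oc2c1` and compound 2 the structure `COC(=O)c1c(Br)cc(Br)cc1OC(=O)COc1cc(O)c2c(=O)cc(-c3ccccc3)oc2c1`. In an ADME assay on cells (T-cell, Mus musculus, strain BALB/c) for cytotoxicity, read by MTT assay, with a stated time of 48 h (on this read-out lower numbers stand for higher toxicity in this test and higher numbers for lower toxicity in this test), compound 1 gives 265000 nM, while compound 2 gives 398000 nM. These two numbers lie within the usual scatter of each other, so neither compound can be called more or less toxic than the other on this evidence; both sit at concentrations far above what is usually thought of as potent toxicity.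

Compound 3, with the structure `COC(=O)c1cccc(C)c1OC(=O)COc1cc(O)c2c(=O)cc(-c3ccccc3)oc2c1`, has not yet been measured. It differs from compound 1 in one place: a group of 11 heavy atoms (9 carbon, 2 oxygen; one six-membered aromatic ring of carbon only) in place of a group of 11 heavy atoms (8 carbon, 2 oxygen, 1 chlorine; one six-membered aromatic ring of carbon only), on an oxygen next to a carbonyl group. Going by the values given here, no pair of measured compounds shows what this kind of exchange does in this assay, so there is no directly comparable step to lean on. The expected step from compound 1 to compound 3 is therefore no change at the digits printed from compound 1 to compound 3 (within the scatter), that is, none beyond the scatter. The estimate for compound 3 in this assay is 265000 nM, with a range from 130000 nM to 530000 nM.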

Compound 3, half-maximal cytotoxic concentration: 299000 nM
The estimate for compound 3 lay 1.1-fold (0.05 log units) below the measured number; measured number inside the range.
By their numbers in this assay, from the lowest: compounds 1, 3 and 2 (each within the scatter of the next).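

In this assay, replacing the 5-chloro-2-(methoxycarbonyl)phenyl group, on an oxygen next to a carbonyl group, with a group that carries no chlorine gives a 1.1-fold higher number from compound 1 to compound 3 (0.05 log units; within the scatter). Going by these compounds alone, this is the first single-place exchange that can be read at this position, and it shows that losing the chlorine, with one more carbon in the group, leaves the number within the scatter. Nothing available explains why this exchange has so little effect.

A single step cannot show how far this tolerance extends, and an amine or a carboxylic acid on the aromatic ring of this group might behave quite differently. Going by these compounds, whether a longer chain at this place would shift the number beyond the scatter also remains open.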